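Trifluoromethoxy for Benzyl on the Sulfonamide Aryl Ring

A few compounds are considered here, and "the series" means these few. Any claim that something is new, unique, unknown or untested is made for them only; others in the source may bear on it.

compound 1, `CCS(=O)(=O)N(Cc1cccnc1)c1ccc(Cc2ccccc2)cc1`: 1600 nM
compound 2, `CCS(=O)(=O)N(Cc1cccnc1)c1cccc(Cc2ccccc2)c1`: 310 nM

Both numbers come from an assay on isolated protein with metabotropic glutamate receptor 2 (Homo sapiens) as the target; on this read-out higher numbers stand for an effect only at larger amounts of compound and lower numbers for an effect already at smaller amounts. Compound 2 holds the lower of the two values; its nearest neighbour is compound 1, and the gap between them lies beyond the usual scatter. Compound 3, `CCS(=O)(=O)N(Cc1cccnc1)c1cccc(OC(F)(F)F)c1`, has not yet been measured in this assay. Against compound 2 it shows (trifluoromethoxy in place of benzyl on an aromatic carbon). No step between two measured compounds covers this kind of exchange, so the size of the effect cannot be read from the data shown. Among the compounds with values here, the expectation for compound 3 is a step of a 2.9-fold higher number from compound 2 to compound 3 (0.46 log units; beyond the scatter) toward a weaker effect, with a wide range, since the only measured change in the set concerns where the benzyl group sits and not whether it is present. Compound 3 is accordingly estimated at 900 nM, with a range from 250 nM to 3500 nM.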

Compound 3, half-maximal effective concentration: 1600 nM
Beside the measured number, compound 3's estimate is 1.8-fold (0.25 log units) below it, and the stated range covers the measured number.
By their numbers in this assay, from the lowest: compound 2; then compounds 1 and 3 (each within the scatter of the next).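

Replacing benzyl with trifluoromethoxy on this aromatic carbon gives a 5.2-fold higher number from compound 2 to compound 3 (0.71 log units; beyond the scatter) in this assay. The position therefore responds to which group it carries, whereas the earlier pair showed only that the placement of benzyl matters. Benzyl brings a six-membered aromatic ring of carbon only and trifluoromethoxy has no ring, but this single exchange cannot separate the loss of that ring from the other differences between the two groups, and no available data explain the step.

Open, from the compounds shown here alone, is whether phenoxy, a directly attached phenyl ring or a plain methyl on this carbon would hold the number seen for compound 2. Also open, going by these compounds, is how trifluoromethoxy would compare with benzyl at the position benzyl occupies in compound 1.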